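A few compounds are considered here, and "the series" means these few. Any claim that something is new, unique, unknown or untested is made for them only; others in the source may bear on it.

In a functional assay on SW-620 cells (Homo sapiens) for cytotoxicity, read by MTT assay, with a stated time of 72 h (a higher number here means a weaker inhibitor, a lower number a stronger inhibitor), compound 3 `COc1ccc(/C=C2\CCC/C(=C\c3ccc(Cl)cc3)C2=O)cc1OC` gives 5900 nM, and compound 2 `COc1cc(/C=C2\CCC/C(=C\c3cccc(OC)c3OC)C2=O)ccc1O` gives 8600 nM, two values within the scatter of each other. Compound 1 `COc1ccc(/C=C2\CCC/C(=C\c3cccc(OC)c3OC)C2=O)c(OC)c1` reports only a limit, > 20000 nM. Compound 4 `COc1ccccc1/C=C1\CCC/C(=C\c2ccc(OC)c(OC)c2)C1=O` has not yet been measured. Relative to compound 3, it carries 2-methoxyphenyl in place of 4-chlorophenyl on a double-bonded chain carbon bound to a double-bonded ring carbon. Going by the values given here, no measured pair isolates this change, so only a modest move toward a higher number in this assay is expected, about the size of the scatter. That direction leans on compound 1, also carrying only methoxy groups on its aromatic rings, with its limit of > 20000 nM. The expected step is a 1.7-fold higher number from compound 3 to compound 4 (0.23 log units; within the scatter). For compound 4 the estimated value is 10000 nM, with an expected range of 4000 nM to 20000 nM.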

Compound 4, half-maximal inhibitory concentration: 7800 nM
For compound 4 the middle estimate is 1.3-fold (0.11 log units) above the measured one; the range from low to high includes it.
By their numbers in this assay, from the lowest: compounds 3, 4 and 2 (each within the scatter of the next). At a limit, above all of these: compound 1.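

In this assay, going by these compounds alone, the exchange of 4-chlorophenyl for 2-methoxyphenyl gives a 1.3-fold higher number from compound 3 to compound 4 (0.12 log units; within the scatter) and so offers the first reading of a change in one place. At this position, the chlorine-bearing ring and the methoxy-bearing ring cannot be told apart by this read-out. Compound 1 remains a limit and gives no number to set against this step: the limit of > 20000 nM in this assay, at which 1 of the 4 values shown sits.

Going by these compounds, whether any group on this double-bonded chain carbon can move the value beyond the scatter stays open. An aminophenyl or a carboxyphenyl ring in this place might answer that.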